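Replacing a distal aryl thiourea with an acyl ketone chain

This account rests on a few compounds, and the source may have more. Where it says the series, first, only, none or still open, it means among the compounds named here.

Within the data shown here, the three compounds measured so far share one core and differ only in the tail that hangs from the saturated chain carbon two bonds along from the amide-type nitrogen. Compound 1 `CCCn1c(=O)c2nc(-c3ccc(OCC(=O)NCCN=C(S)Nc4ccc(C)cc4)cc3)[nH]c2n(CCC)c1=O` gives 16 nM in an assay on brain for binding affinity to adenosine receptor A1 (Rattus norvegicus), read by radioligand binding (a lower number here means a stronger inhibitor, a higher number a weaker inhibitor), which places it second highest among the three numbers: compound 3 `CCCn1c(=O)c2nc(-c3ccc(OCC(=O)NCCNC(=O)C/N=C(\S)Nc4ccc(N=C=S)cc4)cc3)[nH]c2n(CCC)c1=O` gives 6.85 nM and compound 2 `CCCn1c(=O)c2nc(-c3ccc(OCC(=O)NCCNS(=O)(=O)c4ccc(C)cc4)cc3)[nH]c2n(CCC)c1=O` gives 72 nM. Among the measured compounds shown here, the one step that changes a single place, a 4.5-fold higher number from compound 1 to compound 2 (0.65 log units; beyond the scatter), shows that swapping the aryl thiourea tail of compound 1 for a sulfonamide tail costs a modest amount of affinity.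

Compound 4 `CCCn1c(=O)c2nc(-c3ccc(OCC(=O)NCCNC(=O)CCCCC(C)=O)cc3)[nH]c2n(CCC)c1=O` makes a bolder change at the same place: a group of 10 heavy atoms (7 carbon, 1 nitrogen, 2 oxygen; no ring) in place of a group of 11 heavy atoms (8 carbon, 2 nitrogen, 1 sulfur; one six-membered aromatic ring of carbon only), on a saturated chain carbon, two bonds along the chain from an amide-type nitrogen. The aromatic ring and both thiourea nitrogens leave, and an open chain ending in a ketone enters. Because the step of a 4.5-fold higher number from compound 1 to compound 2 (0.65 log units; beyond the scatter) already lost affinity while keeping an aromatic ring, a somewhat larger loss is expected for compound 4, estimated as a 2.8-fold higher number from compound 1 to compound 4 (0.45 log units; beyond the scatter). Compound 4 is therefore expected to give about 45 nM in this assay, within a range from 14 nM to 140 nM.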

Compound 4, inhibition constant: 44 nM
Estimate against measurement, compound 4: 1.0-fold (0.01 log units) above; measured number inside the range.
By their numbers in this assay, from the lowest: compound 3; then compound 1; then compounds 4 and 2 (each within the scatter of the next).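

In this assay, the step of a 2.8-fold higher number from compound 1 to compound 4 (0.44 log units; beyond the scatter) is no larger than a modest loss, which shows that this position keeps much of its affinity with an open chain that has no ring and ends in a ketone. The step of a 1.6-fold lower number from compound 2 to compound 4 (0.21 log units; within the scatter) leaves the (4-acetylbutyl)carbonyl tail and the (4-methylphenyl)sulfonyl tail indistinguishable in this measurement, even though only one of them carries an aromatic ring. Nothing available explains these results.

Compound 4 differs from compound 1 in both the ring and the thiourea nitrogens, so what the compounds shown leave open is which of these accounts for the step. They also leave open whether the ketone itself matters, and how a tail ending in an amine or a carboxylic acid, or a longer chain, would read in this assay at this position.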